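The compounds below may be only part of what the source reports. "The series", "measured", "known", "first", "only" and "open" are said of these compounds alone.

Compound 1 `CCOC(=O)COCn1cc(/C=C/Br)c(=O)[nH]c1=O`: > 200000 nM, a limit
Compound 2 `O=c1[nH]c(=O)n(COCCO)cc1/C=C/Br`: > 200000 nM, a limit
Compound 3 `O=c1ccn(C[C@@H]2CCC[C@H]2CO)c(=O)[nH]1`: > 200000 nM, a limit

In an ADME assay on L1210/0 cells (Mus musculus) for cytotoxicity, with a stated time of 48 h (on this read-out higher numbers stand for weaker inhibition and lower numbers for stronger inhibition), compound 2 reads > 200000 nM, which is a limit and not a number. The other two compounds give no number either, and the whole record comes down to one observation: the limit of > 200000 nM in this assay, at which 3 of the 3 values shown sit. Compound 2 therefore has no exact place on the scale.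

The compound still to be measured is compound 4 `Cc1cn(COCCO)c(=O)[nH]c1=O`. It keeps the (2-hydroxyethoxy)methyl group of compound 2 and carries methyl in place of 2-bromoethenyl on an aromatic carbon.

Going by the values given here, only one measured step exists: a step that the two limits leave unreadable from compound 1 to compound 2. That step concerns the chain and not the group changing here, and its size cannot be read, so it offers no guide to size. Among the compounds with values here, no measured step touches the 2-bromoethenyl group.

The expectation therefore rests on compound 2 with > 200000 nM, a limit, and another limit is the likeliest result. The expected size in this assay is a number no higher from compound 2 to compound 4 (the limit leaves the size open), with no step in either direction beyond the scatter. The estimated value for compound 4 is 200000 nM, expected within 80000 nM to 500000 nM.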

Compound 4, half-maximal inhibitory concentration: > 200000 nM
Compound 4 was reported as a limit; the forecaster's own chance of this, stated with the estimate: 85%; the middle value lies on the limit itself.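

Compound 2 and compound 4 both give limits rather than numbers in this assay, so no new step can be read between them. Still open is how strongly any of the four compounds inhibits these cells, and whether methyl in place of 2-bromoethenyl changes that at all, since the record holds a single observation: the limit of > 200000 nM in this assay, at which 4 of the 4 values shown sit.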